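The compounds below may be only part of what the source reports. "The series", "measured", "known", "first", "only" and "open" are said of these compounds alone.

The measured compounds and their values:

Compound 1 `COc1ccc(-c2[nH]c3ccccc3c2/C=C(\C#N)S(=O)(=O)c2ccccc2)cc1`: in a functional assay on HepG2 cells (Homo sapiens) for cytotoxicity, read by MTT assay, with a stated time of 96 h (a lower number here means that less compound is needed, a higher number that more compound is needed for the effect), compound 1 gives 11000 nM.
Compound 2 `N#C/C(=C\c1c(-c2ccccc2)[nH]c2ccccc12)C(=O)c1cccs1`: in this assay compound 2 gives 25000 nM.
Compound 3 `CCOC(=O)/C(=C/c1c(-c2ccccc2)[nH]c2ccccc12)C(=O)c1ccc([N+](=O)[O-])cc1`: in this assay compound 3 gives 28000 nM.

All three compounds share the same core, an indole bearing an aryl group and a substituted alkene, and they differ in what hangs on that alkene. Among the three numbers, compound 2 stands second highest. Its nearest neighbour is compound 3, whose value lies within the usual scatter of compound 2, so the two cannot be told apart. Compound 1 gives the lowest number, and its distance from compound 2 lies beyond the scatter.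

Compound 4 `COCCOC(=O)/C(C#N)=C/c1c(-c2ccccc2)[nH]c2ccccc12` has not yet been measured. It differs from compound 2 in one place: 2-methoxyethoxy in place of thiophen-2-yl on a carbonyl carbon. For the measured compounds named here, no step between measured compounds changes only this part, so there is no direct precedent. The three measured values all fall in a narrow band, and nothing in them points to a large shift in either direction. The step from compound 2 to compound 4 is therefore expected to be small, a 1.2-fold higher number from compound 2 to compound 4 (0.08 log units; within the scatter), not beyond the scatter. For compound 4 the estimate is 30000 nM, with a plausible range from 12000 nM to 75000 nM.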

Compound 4, half-maximal effective concentration: 85000 nM
For compound 4 the middle estimate is 2.8-fold (0.45 log units) below the measured one; measured number outside the range, above it.
By their numbers in this assay, from the lowest: compound 1; then compounds 2 and 3 (each within the scatter of the next); then compound 4.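

For the compounds shown here, the carbonyl carbon is not a silent position: in this assay, 2-methoxyethoxy in place of thiophen-2-yl gives a 3.4-fold higher number from compound 2 to compound 4 (0.53 log units; beyond the scatter) and this is the first change at a single place that can be read at all. Going by these compounds alone, until this pair, no two measured compounds differed in one place, so the values could not show whether this site mattered; now it is clear that replacing a five-membered aromatic ring with a chain that has no ring can raise the amount of compound needed for the effect on these cells. Nothing measured here explains why the number moves.

This one step changes several things at once, since the ring goes, sulfur gives way to oxygen, and the count of hydrogen-bond acceptors differs, and the compounds shown cannot separate these. A furan-2-yl ring on the same carbonyl carbon, or a plain butoxy chain, would be needed to tell whether losing the ring or bringing in the chain goes with the higher number.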